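Cyclopropyl in Place of Trifluoromethyl: What to Expect

The source may report more compounds than this note shows. Statements on the series, on what has been measured and on what is new or still open speak of the compounds shown alone.

Measured so far:
compound 1, `CSc1cc(C)n(C)c(=O)c1CN1CCc2c(Cl)cc(-c3c(C)noc3C)c(Cl)c2C1=O`, in an assay on isolated protein for inhibition of histone-lysine N-methyltransferase EZH2 (Homo sapiens), read by filter binding, with a stated time of 1 h (on this read-out lower numbers stand for stronger inhibition and higher numbers for weaker inhibition), gives 1.3 nM
compound 2, `Cc1noc(C)c1-c1cc(Cl)c2c(c1Cl)C(=O)N(Cc1c(C(F)(F)F)cc(C)n(C)c1=O)CC2`, in this assay gives > 1000 nM
compound 3, `Cc1cc(C)c(CN2CCc3c(Cl)cc(-c4c(C)noc4C)c(Cl)c3C2=O)c(=O)[nH]1`, in this assay gives 1 nM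

Compound 2 reports no number, only (the limit of > 1000 nM in this assay, at which 1 of the 3 values shown sits). Compound 4, `Cc1noc(C)c1-c1cc(Cl)c2c(c1Cl)C(=O)N(Cc1c(C3CC3)cc(C)n(C)c1=O)CC2`, differs from compound 2 by cyclopropyl in place of trifluoromethyl on an aromatic carbon. For the measured compounds named here, the only measured step at this position is an at least 760-fold higher number from compound 1 to compound 2 (2.88 log units; beyond the scatter), a large loss that runs into the limit, so it cannot show how far a cyclopropyl will move the value back. Compounds 1 and 3 show that methylsulfanyl and methyl at this position both give low numbers. A large step downward, from the limit toward those values, is therefore expected: an at least 100-fold lower number from compound 2 to compound 4 (2.00 log units; beyond the scatter). Compound 4 is estimated at 10 nM, within a range from 2 nM to 100 nM.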

Compound 4, half-maximal inhibitory concentration: 302 nM
The estimate for compound 4 lay 30-fold (1.48 log units) below the measured number; the measured number lies above the stated range.
By their numbers in this assay, from the lowest: compounds 3 and 1 (each within the scatter of the next); then compound 4. At a limit, above all of these: compound 2.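

The change gives an at least 3.3-fold lower number from compound 2 to compound 4 (0.51 log units; beyond the scatter), so cyclopropyl restores part of what trifluoromethyl loses at this position. Compound 2 stands only at a limit of the assay: the limit of > 1000 nM in this assay, at which 1 of the 4 values shown sits. Cyclopropyl still falls well short of methylsulfanyl, with a 230-fold higher number from compound 1 to compound 4 (2.37 log units; beyond the scatter), so this position separates groups more finely than the earlier compounds could show.

The compounds shown do not tell why these groups differ. On these data alone, how a methoxy group, an ethyl group or an amine would fare at this position also remains open.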